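Trimming the ester chain of compound 1

The source may report more compounds than this note shows. Statements on the series, on what has been measured and on what is new or still open speak of the compounds shown alone.

For the measured compounds named here, in a functional assay (strain AB) with Danio rerio as the target, read by microscopy, with a stated time of 1 h (on this read-out higher numbers stand for an effect only at larger amounts of compound and lower numbers for an effect already at smaller amounts), compound 1 (`CC(C)(C)OC(=O)CCC[N+]1(C)CCc2c(sc(NC(=O)Nc3ccc(Cl)cc3)c2C(N)=O)C1`) gives 250 nM and holds the lower of the two numbers measured so far. Compound 2 (`NC(=O)c1c(NC(=O)Nc2ccc(Cl)cc2)sc2c1CCN(CC1CCCCC1)C2`) gives 1890 nM which is clearly higher, though it differs from compound 1 in more than one place. The next candidate is compound 3 (`CC(C)(C)C[N+]1(C)CCc2c(sc(NC(=O)Nc3ccc(Cl)cc3)c2C(N)=O)C1`). Its change from compound 1 reads tert-butyl in place of 2-(tert-butoxycarbonyl)ethyl on a saturated chain carbon bound to an amine nitrogen in a ring and amounts to tert-butyl in place of 2-(tert-butoxycarbonyl)ethyl on a saturated chain carbon bound to an amine nitrogen in a ring. Going by the values given here, no measured pair isolates a change like this, so the expectation is loose. Compound 2 also lacks the tert-butoxycarbonyl group and reads higher, which points upward. A moderate rise is expected in this assay with an estimated size of a 2.0-fold higher number from compound 1 to compound 3 (0.30 log units; within the scatter) and a real chance of staying within the scatter. Compound 3 is estimated at 500 nM (130 nM to 1900 nM).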

Compound 3, half-maximal effective concentration: 290 nM
Compound 3: middle estimate off by 1.7-fold (0.24 log units), on the high side, and the stated range covers the measured number.
By their numbers in this assay, from the lowest: compounds 1 and 3 (each within the scatter of the next); then compound 2.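

In this assay, putting tert-butyl in place of 2-(tert-butoxycarbonyl)ethyl on a saturated chain carbon bound to an amine nitrogen in a ring gives a 1.2-fold higher number from compound 1 to compound 3 (0.06 log units; within the scatter) and the two compounds cannot be told apart. The ester, with its carbonyl and both of its oxygens, can therefore be removed from this chain without costing anything measurable on this read-out, and a shorter all-carbon neopentyl group serves as well as the 3-(tert-butoxycarbonyl)propyl group. No measurement available here explains why the two compounds read alike.

On these data alone, it remains open whether a carboxylic acid in place of the ester, an amine at the chain end or a longer plain carbon chain would also read the same. No pair shown isolates the methyl group on the same nitrogen either, so its contribution is still unknown.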